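The source may hold more compounds than are shown below. What is called first, only, known or untested is meant among the compounds shown, and "the series" means these compounds.

Series notes on the quinone acids in a functional assay on HeLa cells (Homo sapiens) for cytotoxicity, read by MTT assay, with a stated time of 72 h; on this read-out lower numbers stand for stronger inhibition and higher numbers for weaker inhibition.

For the measured compounds named here, compound 1 `CC(C)(C)C1=CC(=O)C=C(NCC(=O)O)C1=O` is the smallest member and gives 132000 nM in this assay; this is the highest of the three numbers so far. Compound 3 `CC1=CCC[C@H]2[C@](C)(CC3=CC(=O)C=C(NCC(=O)O)C3=O)[C@@H](C)CC[C@]12C` carries the same glycine-type side chain on a larger core and gives 19900 nM. How the core of compound 1 and the core of compound 3 differ is not broken down here. Compound 2 `CC1=CCC[C@H]2[C@](C)(CC3=CC(=O)C=C(N[C@@H](CC(C)C)C(=O)O)C3=O)[C@@H](C)CC[C@]12C` is compound 3 with isobutyl in place of hydrogen on a saturated chain carbon bound to an amine nitrogen and a carbonyl carbon. In this assay compound 2 gives 7720 nM; the step of a 2.6-fold lower number from compound 3 to compound 2 (0.41 log units; beyond the scatter) is modest but beyond the scatter.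

Compound 4 `CC(C)C[C@H](NC1=CC(=O)C=C(C(C)(C)C)C1=O)C(=O)O` is not yet measured. It stands to compound 1 as compound 2 stands to compound 3: isobutyl in place of hydrogen on a saturated chain carbon bound to an amine nitrogen and a carbonyl carbon. The place lines read the same word for word, so this is the same change made on the smaller core. Going by the values given here, the step is expected to be of similar size, a 2.6-fold lower number from compound 1 to compound 4 (0.42 log units; beyond the scatter), resting on the one measured instance a 2.6-fold lower number from compound 3 to compound 2 (0.41 log units; beyond the scatter) from compound 3 to compound 2, with wide uncertainty since the cores differ. Compound 4 is thus estimated at 50000 nM, in a range from 18000 nM to 140000 nM.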

Compound 4, half-maximal inhibitory concentration: 57200 nM
Compound 4: the middle estimate sits 1.1-fold (0.06 log units) below what was measured, within the range that was stated.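

The isobutyl change also lowers the number on the smaller core in this assay, with a 2.3-fold lower number from compound 1 to compound 4 (0.36 log units; beyond the scatter). Across the two cores, the step carries over with no difference that can be told apart: the same change on two cores in this assay, a 2.6-fold lower number (0.41 log units; beyond the scatter) from compound 3 to compound 2 and a 2.3-fold lower number (0.36 log units; beyond the scatter) from compound 1 to compound 4, 1.1-fold (0.05 log units) apart, within the scatter of two such steps. For the compounds shown here, this rests on only two pairs and one entering group, so it does not show that the step would hold on a third core, or that another group at this place would behave alike on both cores.

Open, as far as these compounds go, is whether a methyl group, a benzyl group or a longer chain ending in an amine, in place of hydrogen on the same saturated chain carbon, would shift the number by a similar step on both cores. Also open, from the compounds shown here alone, is whether the step survives when the carboxylic acid gives way to a methyl ester or an amide.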